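Chloro on the benzyl ring of a bis(trifluoromethyl)benzenesulfonamide

The source may report more compounds than this note shows. Statements on the series, on what has been measured and on what is new or still open speak of the compounds shown alone.

Measured so far:
compound 1, `O=S(=O)(NCCCCNCc1ccc(Br)cc1)c1cc(C(F)(F)F)cc(C(F)(F)F)c1`: 2100 nM
compound 2, `COc1ccc(CNCCCNS(=O)(=O)c2cc(C(F)(F)F)cc(C(F)(F)F)c2)cc1OC`: 3800 nM
compound 3, `O=S(=O)(NCCCNCc1ccccc1)c1cc(C(F)(F)F)cc(C(F)(F)F)c1`: 4900 nM

Three sulfonamides share a core, and all were read in a functional assay on A2780 cells (Homo sapiens) for inhibition, read by MTT assay, with a stated time of 72 h; a higher number here means a weaker inhibitor of growth, a lower number a stronger inhibitor of growth. Compound 3 gives the highest number of the three; compound 2 sits within the scatter of it, while compound 1 is further off, as a 2.3-fold higher number from compound 1 to compound 3 (0.37 log units; beyond the scatter) shows. The step of a 1.3-fold higher number from compound 2 to compound 3 (0.11 log units; within the scatter) is too small to count as a change.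

Compound 4, `O=S(=O)(NCCCNCc1cccc(Cl)c1)c1cc(C(F)(F)F)cc(C(F)(F)F)c1`, differs from compound 3 by chloro in place of hydrogen on an aromatic carbon. Among the compounds with values here, no measured step adds a halogen alone to this ring. The nearest comparison is compound 1, which carries a bromine on its benzyl ring together with a longer chain; its step of a 2.3-fold higher number from compound 1 to compound 3 (0.37 log units; beyond the scatter) is modest and beyond the scatter, but it bundles two changes, so only part of it can be ascribed to the halogen. Compound 2, with two methoxy groups on the same ring, shows no step beyond the scatter.

Compound 4 is therefore expected to come in a little below compound 3 in this assay, a step of a 1.6-fold lower number from compound 3 to compound 4 (0.21 log units; within the scatter), at about 3000 nM, within a range of 1400 nM to 7000 nM.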

Compound 4, concentration for 50% growth inhibition: 2200 nM
Compound 4: the middle estimate sits 1.4-fold (0.13 log units) above what was measured; measured number inside the range.
By their numbers in this assay, from the lowest: compounds 1, 4, 2 and 3 (each within the scatter of the next, the first and the last beyond it).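

In this assay, a 2.2-fold lower number from compound 3 to compound 4 (0.35 log units; beyond the scatter) is the first step among these compounds that changes only the benzyl ring and lies beyond the scatter, and it takes no more than chloro in place of hydrogen on an aromatic carbon, although the step remains modest. The other two comparisons do not separate the new 3-chlorobenzyl compound from its neighbours: a 1.7-fold lower number from compound 2 to compound 4 (0.24 log units; within the scatter) swaps 3,4-dimethoxyphenyl for 3-chlorophenyl, and a 1.0-fold higher number from compound 1 to compound 4 (0.02 log units; within the scatter) swaps ((4-bromobenzyl)amino)methyl for (3-chlorobenzyl)amino, both within the scatter, so the single chloro on the unchanged chain covers a gap as large as the bundled change in compound 1 did. No independent evidence bears on this result.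

The compounds shown leave open whether the step depends on where the halogen sits, as a 4-chlorobenzyl or 2-chlorobenzyl group would show, and whether fluoro, bromo or methyl at the same place would give a similar step. They also leave open how much the chain contributes, which the 3-chlorobenzyl group on a longer chain, or the 4-bromobenzyl group on the chain of compound 3, would separate from the ring change.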